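The source may hold more compounds than are shown below. What is called first, only, known or untested is meant among the compounds shown, and "the series" means these compounds.

In a physicochemical assay, with a stated time of 30 min (a higher number here means a weaker inhibitor, a lower number a stronger inhibitor), compound 1 (`C/C(=N\N=C1/SCC(=O)N1Cc1cccc(Cl)c1)c1cccs1`) gives > 5000000 nM as a limit of the assay and not as a number. Compound 2 (`O=C1CS/C(=N\N=C2CCCC2)N1Cc1ccccc1F`) gives > 5000000 nM as a limit too, so no number is available for it. That is all the record holds so far: the limit of > 5000000 nM in this assay, at which 2 of the 2 values shown sit, and no measured value below it. Neither compound can therefore be ranked against the other.

Compound 3 (`O=C1CS/C(=N\N=C2CCCC2)N1Cc1ccc(Cl)cc1`) departs from compound 2 in one place, with 4-chlorophenyl in place of 2-fluorophenyl on a saturated chain carbon bound to an amide-type nitrogen in a ring. Among the measured compounds shown here, no step between measured compounds is available to size such an exchange. The expectation therefore starts from compound 2 and its limit of > 5000000 nM in this assay and looks for no change beyond the scatter in either direction. The expected step is a number no higher from compound 2 to compound 3 (the limit leaves the size open) on this reading, and compound 3 may well be reported only as a limit again. For compound 3 the estimated value is 5000000 nM with an expected range from 1000000 nM to 8000000 nM for a single measurement.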

Compound 3, half-maximal inhibitory concentration: > 5000000 nM
Compound 3: no number, only a limit (the forecaster's own chance of this, stated with the estimate: 75%); the middle value sits exactly at the limit.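

No step can be read from compound 2 to compound 3, since both stop at a limit in this assay and the exchange of 2-fluorophenyl for 4-chlorophenyl therefore has no readable size. The compounds shown leave open how any of them ranks against another, and what would bring a measured number into reach: the limit of > 5000000 nM in this assay, at which 3 of the 3 values shown sit.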